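A few compounds are considered here, and "the series" means these few. Any claim that something is new, unique, unknown or untested is made for them only; others in the source may bear on it.

Among the measured compounds shown here, compound 1 `COc1ccc(C(=O)/C=C/c2ccc(OCc3cn(Cc4ccccc4F)nn3)cc2)cc1` stands at the top of the two numbers measured so far in a functional assay on HepG2 cells (Homo sapiens) for inhibition, read by MTT assay, with a stated time of 48 h, tested at 10 uM (a higher number here means more inhibition of growth at the concentration tested, a lower number less inhibition of growth), where compound 1 gives 33%. For the measured compounds named here, its only measured neighbour, compound 2 `COc1ccc(C(=O)/C=C/c2ccc(OCc3cn(Cc4cccc(F)c4)nn3)cc2)cc1`, gives 22% in this assay, and the one measured step, a number 11 percentage points lower from compound 1 to compound 2 (beyond the scatter), concerns the fluorophenyl group on the saturated chain carbon bound to the aromatic nitrogen, a part of the shared core that is left untouched in what follows.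

Compound 3 `O=C(/C=C/c1ccc(OCc2cn(Cc3ccccc3F)nn2)cc1)c1ccc([N+](=O)[O-])cc1` differs from compound 1 in another place: nitro in place of methoxy on an aromatic carbon. Going by the values given here, no measured pair in this set changes that position, so the step from compound 1 to compound 2 does not bear on it, and there is nothing in the data from which a direction for this change can be read. The account therefore takes the value of compound 1 as its anchor and expects no step beyond the scatter, with a wide range to reflect the lack of any comparable pair: compound 3 is estimated at 33% in this assay, somewhere between 10% and 60%, which means an expected step of no change at the digits printed from compound 1 to compound 3 (within the scatter).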

Compound 3, percent growth inhibition at one concentration: 22%
Estimate against measurement, compound 3: 11 percentage points above; measured number inside the range.
By their numbers in this assay, from the lowest: compounds 2 and 3 (each within the scatter of the next); then compound 1.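

The position on the aromatic carbon para to a large group, which the earlier pair left untouched, now has a measured change: in this assay, nitro in place of methoxy gives a number 11 percentage points lower from compound 1 to compound 3 (beyond the scatter), a modest step beyond the scatter. This shows that the number responds to what this place carries, not only to the fluorophenyl group changed in the earlier pair, and that of these two groups, the methoxy of compound 1 goes with the higher number. Nothing available bears on why the number moves with this change.

A single pair gives a direction for these two groups only, so the compounds shown leave open how an amine, a hydroxyl group or a carboxylic acid at the same place would compare with the methoxy of compound 1. Among the compounds shown here, they also leave open whether the change from 4-methoxyphenyl to 4-nitrophenyl would give a similar step on the 3-fluorophenyl background of compound 2, since the one measured pair at this position carries the 2-fluorophenyl group.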